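This account rests on a few compounds, and the source may have more. Where it says the series, first, only, none or still open, it means among the compounds named here.

Measured in an ADME assay on microsomes from liver (Homo sapiens) for metabolic stability, read by LC-MS, tested at 1 uM; on this read-out higher numbers stand for fast clearance and lower numbers for slow clearance:

Compound 1 `NCCCCCOc1ccc([C@H]2CC[C@]3(CC2)OOC2(O3)C3CC4CC(C3)CC2C4)cc1`: < 7 mL.min-1.g-1 (a limit of the assay)
Compound 2 `NCCOCCOc1ccc([C@H]2CC[C@]3(CC2)OOC2(O3)C3CC4CC(C3)CC2C4)cc1`: < 7 mL.min-1.g-1 (a limit of the assay)
Compound 3 `OC1(COc2ccc([C@H]3CC[C@]4(CC3)OOC3(O4)C4CC5CC(C4)CC3C5)cc2)CCNCC1`: 16 mL.min-1.g-1

Compound 3 is the only one of the three with a true number. The other two compounds rest on (the limit of < 7 mL.min-1.g-1 in this assay, at which 2 of the 3 values shown sit), which is a limit and not a number.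

The next compound is compound 4 `c1cc([C@H]2CC[C@]3(CC2)OOC2(O3)C3CC4CC(C3)CC2C4)ccc1OCCC1CCNCC1`, and its difference from compound 3 is (piperidin-4-yl)methyl in place of 4-hydroxypiperidin-4-yl on a saturated chain carbon bound to an oxygen on an aromatic ring. In words, (piperidin-4-yl)methyl stands in place of 4-hydroxypiperidin-4-yl on a saturated chain carbon bound to an oxygen on an aromatic ring.

Going by the values given here, no measured step makes this exchange directly. The nearest evidence is an at least 2.2-fold higher number from compound 1 to compound 3 (0.35 log units; beyond the scatter) and an at least 2.2-fold higher number from compound 2 to compound 3 (0.35 log units; beyond the scatter), each of which brings in 4-hydroxypiperidin-4-yl in place of an open chain. The remaining step, a step that the two limits leave unreadable from compound 1 to compound 2, offers no usable size.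

Compound 4 keeps a six-membered non-aromatic ring with 1 hetero atom, so it is expected to stay nearer to compound 3 at 16 mL.min-1.g-1 than to the open-chain compounds. No change beyond the scatter is therefore expected in this assay, and the estimated step is a 1.1-fold lower number from compound 3 to compound 4 (0.03 log units; within the scatter). The expected value for compound 4 is 15 mL.min-1.g-1, with an estimated range from 7 mL.min-1.g-1 to 38 mL.min-1.g-1.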

Compound 4, intrinsic clearance in microsomes: < 7 mL.min-1.g-1
Compound 4: a limit, no number (the forecaster's own chance of this, stated with the estimate: 20%); middle value at least 2.1-fold (0.33 log units) away from the limit.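

In this assay, (piperidin-4-yl)methyl in place of 4-hydroxypiperidin-4-yl gives an at least 2.2-fold lower number from compound 3 to compound 4 (0.35 log units; beyond the scatter), so the six-membered non-aromatic ring with 1 hetero atom, which both groups carry, does not by itself go with the higher number. Going by these compounds alone, the earlier compounds could not show this, as their only readable steps set 4-hydroxypiperidin-4-yl against open chains, whereas here the two groups have the same 7 heavy atoms and differ in their atoms, with 6 carbon and no oxygen entering, and in having 1 hydrogen-bond donor rather than 2 hydrogen-bond donors. The value of compound 4 is a limit, so the steps joining compound 1, compound 2 and compound 4 cannot be read, and all three rest on the same line: the limit of < 7 mL.min-1.g-1 in this assay, at which 3 of the 4 values shown sit.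

On these data alone, how far the true number of compound 4 lies from that limit stays open, and the size of its step is therefore known from one side only. The exchange also removes the hydroxyl and lengthens the link together, so a plain piperidin-4-yl on a saturated chain carbon bound to an oxygen on an aromatic ring would be needed to tell these two changes apart.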